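This account rests on a few compounds, and the source may have more. Where it says the series, first, only, none or still open, it means among the compounds named here.

Measured so far:
compound 1 `Cc1ccc(NCc2cn(-c3ccccc3)nc2-c2ccc(Cl)cc2)cc1` — > 100000 nM
compound 2 `Clc1ccc(NCc2cn(-c3ccccc3)nc2-c2ccc(Br)cc2)cc1` — > 100000 nM; > 100000 nM (2 entries)
compound 3 `Cc1ccc(NCc2cn(-c3ccccc3)nc2-c2ccc(Br)cc2)cc1` — > 100000 nM

In an ADME assay on MDBK cells (Bos taurus) for cytotoxicity, read by MTT assay, with a stated time of 72 h (on this read-out higher numbers stand for lower toxicity in this test and lower numbers for higher toxicity in this test), compound 1 gives > 100000 nM, a limit of the assay rather than a number. Compound 2 gives > 100000 nM; > 100000 nM (2 entries) in two entries, both limits. Compound 3 likewise gives only a limit, > 100000 nM. Within the data shown here, the one step between measured compounds, a step that the two limits leave unreadable from compound 1 to compound 3, is therefore unreadable; compound 3 stands at the limit of > 100000 nM in this assay, at which 2 of the 3 values shown sit.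

Compound 4 `Cc1ccc(NCc2cn(-c3ccccc3)nc2-c2ccc(C(F)(F)F)cc2)cc1` differs from compound 3 by trifluoromethyl in place of bromo on an aromatic carbon. Among the measured compounds shown here, no measured step involves trifluoromethyl, and the step from compound 1 to compound 3 bears on this change only as two limits. Compound 4 is therefore expected to remain at the limit as well, with a step that the limit leaves unreadable from compound 3 to compound 4 expected to show no step beyond the scatter. The estimate for compound 4 is 150000 nM, expected to fall between 60000 nM and 400000 nM.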

Compound 4, half-maximal cytotoxic concentration: > 100000 nM
Compound 4: no number, only a limit (the forecaster's own chance of this, stated with the estimate: 80%); the middle value does not contradict the limit.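

In this assay compound 4 gives > 100000 nM, a limit and not a number, so its steps from compound 1 and compound 3 cannot be read. The compounds shown leave open whether chloro, bromo and trifluoromethyl differ at all in this assay beyond this limit.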